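This account rests on a few compounds, and the source may have more. Where it says the series, first, only, none or still open, it means among the compounds named here.

Compound 1 `CCCCC(Sc1nc(Cl)cc(Nc2nc(-c3ccc(Cl)cc3)cs2)n1)C(=O)O` — 3800 nM
Compound 2 `CCCCCCC(Sc1nc(Cl)cc(Nc2nc(-c3ccc(F)cc3F)cs2)n1)C(=O)O` — 2500 nM
Compound 3 `CCCCCCC(Sc1nc(Cl)cc(Nc2nc(-c3ccc([N+](=O)[O-])cc3)cs2)n1)C(=O)O` — 1800 nM

Among these three in an assay for inhibition of Polyunsaturated fatty acid 5-lipoxygenase (Homo sapiens), read by HPLC, with a stated time of 10 min (on this read-out lower numbers stand for stronger inhibition and higher numbers for weaker inhibition), compound 3 stands at the lowest number. Its nearest neighbour is compound 2, and the step of a 1.4-fold lower number from compound 2 to compound 3 (0.14 log units; within the scatter) lies within the scatter, so the two cannot be ordered. Compound 1 gives 3800 nM, whereas compound 3 gives 1800 nM, a gap beyond the scatter.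

Compound 4 `CCCCCCC(Sc1nc(Cl)cc(Nc2nc(-c3ccc(OC)cc3)cs2)n1)C(=O)O` is not yet measured. It differs from compound 3 in one place: methoxy in place of nitro on an aromatic carbon. Among the compounds with values here, the only measured step that bears on a change of this aryl group is a 1.4-fold lower number from compound 2 to compound 3 (0.14 log units; within the scatter), an exchange of one para-substituted aryl for another that stayed within the scatter. Within the data shown here, no measured pair exchanges the nitro for a methoxy, so the data give no ground for expecting a large move in either direction.

The step of a 1.4-fold higher number from compound 3 to compound 4 (0.14 log units; within the scatter) is therefore expected to be small and within the scatter. For compound 4 in this assay the estimate is 2500 nM, with a range from 1000 nM to 6500 nM.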

Compound 4, half-maximal inhibitory concentration: 1800 nM
Beside the measured number, compound 4's estimate is 1.4-fold (0.14 log units) above it, within the range that was stated.
By their numbers in this assay, from the lowest: compounds 3, 4, 2 and 1 (each within the scatter of the next, the first and the last beyond it).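

Methoxy in place of nitro, on an aromatic carbon para to a large group, gives in this assay no change at the digits printed from compound 3 to compound 4 (within the scatter). Within the data shown here, until now this place had been seen only in the exchange of 2,4-difluorophenyl for 4-nitrophenyl, and the new comparison with that same aryl group gives a 1.4-fold lower number from compound 2 to compound 4 (0.14 log units; within the scatter), so 2,4-difluorophenyl, 4-nitrophenyl and 4-methoxyphenyl cannot be told apart among compounds 2, 3 and 4, which differ from one another only in this aryl group. No measurement shown here explains why nitro and methoxy, two groups that differ in their atoms and in their counted hydrogen-bond acceptors, read alike at this place. On these data alone, whether this holds for other groups remains open: an amine, a hydroxyl, a trifluoromethyl or a bare phenyl at the same place could fall inside or outside this narrow band. As far as these compounds go, the part played by the chain also remains open, since compound 1 differs from compounds 2, 3 and 4 in both its chain and its aryl group, so no single change can be read from it.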